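The compounds below may be only part of what the source reports. "The series", "measured", "known", "first", "only" and "open" are said of these compounds alone.

Measured so far:

- Compound 1, `O=c1c(-c2ccc(O)cc2)coc2cc(OCCOCCOCCO)ccc12` — in an assay (Cricetulus griseus) for inhibition of aldehyde dehydrogenase, mitochondrial (Homo sapiens) (a lower number here means a stronger inhibitor, a higher number a weaker inhibitor), compound 1 gives 40 nM
- Compound 2, `CCCCCCOc1ccc2c(=O)c(-c3ccc(O)cc3)coc2c1` — in this assay compound 2 gives 1500 nM
- Compound 3, `O=C(O)COc1ccc(-c2coc3cc(OCC(=O)O)ccc3c2=O)cc1` — in this assay compound 3 gives only a limit, >> 9000 nM

The value of compound 3 is a limit of this assay and not a number; the limit of >> 9000 nM in this assay, at which 1 of the 3 values shown sits, is all that is known of it. Among the two numbers, compound 2 stands highest, and its nearest neighbour is compound 1, which differs only in the chain on the aromatic oxygen: a 38-fold higher number from compound 1 to compound 2 (1.57 log units; beyond the scatter). Trading a chain that ends in a hydroxy group for a plain butyl chain thus moved the number up a long way.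

Compound 4, `NCCCCCCOc1ccc2c(=O)c(-c3ccc(O)cc3)coc2c1`, is compound 2 with one change: amino in place of hydrogen on a saturated chain carbon, six bonds along the chain from an oxygen on an aromatic ring. The chain stays the same length; only a hydrogen-bond donor and acceptor are added at its far end. Within the data shown here, the one step that bears on this is the one from compound 1 to compound 2, where losing a polar chain end went with a large rise. Adding a polar end back is therefore expected to bring the number down, though by less than that step, since the chain itself stays plain. The estimate for compound 4 is 400 nM, with a range from 100 nM to 2000 nM, meaning an expected step of a 3.8-fold lower number from compound 2 to compound 4 (0.57 log units; beyond the scatter).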

Compound 4, half-maximal inhibitory concentration: 100 nM
For compound 4 the middle estimate is 4.0-fold (0.60 log units) above the measured one, and the stated range covers the measured number.
By their numbers in this assay, from the lowest: compound 1; then compound 4; then compound 2. At a limit, above all of these: compound 3.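

In this assay, the far end of the chain turns out to matter a great deal: a 15-fold lower number from compound 2 to compound 4 (1.18 log units; beyond the scatter) comes with nothing more than amino in place of hydrogen, six bonds along the chain from an oxygen on an aromatic ring. The earlier compounds shown here could not show this, since compound 1 and compound 2 differ along their whole chains, whereas here a single added nitrogen at the chain end, on a chain of unchanged length, wins back much of the ground lost by compound 2. The recovery is not complete, though: a 2.5-fold higher number from compound 1 to compound 4 (0.40 log units; beyond the scatter) remains as a modest step that still lies beyond the usual scatter, so the chain ending in amino and the chain ending in hydroxy do not read the same.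

Still open, as far as these compounds go, is whether a shorter or longer chain carrying the same amine, or a hydroxy group or a carboxylic acid at the far end of this same chain, would give a lower or a higher number. Nothing measured here explains why a change at the chain end has a step of this size.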